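Carboxy on the pyrrolidin-1-yl group of compound 3

The source may hold more compounds than are shown below. What is called first, only, known or untested is meant among the compounds shown, and "the series" means these compounds.

Measured in a functional assay on PC-3 cells (Homo sapiens) for inhibition, read by MTT assay, with a stated time of 48 h, tested at 10 uM; on this read-out lower numbers stand for less inhibition of growth and higher numbers for more inhibition of growth at the one concentration tested:
compound 1 `Cc1cc(=O)c2c(O)cc(OCc3ccccc3)c([C@H]3CCN(C)C[C@H]3O)c2o1`: 41%
compound 2 `Cc1cc(=O)c2c(O)cc(OCc3ccco3)c([C@H]3CCN(C)C[C@H]3O)c2o1`: 14%
compound 3 `Cc1cc(=O)c2c(O)c(CN3CCCC3)c(O)c([C@H]3CCN(C)C[C@H]3O)c2o1`: 10%

Compound 3 lies within the scatter of compound 2 and beyond the scatter under compound 1. The change to compound 4 `Cc1cc(=O)c2c(O)c(CN3CCCC3C(=O)O)c(O)c([C@H]3CCN(C)C[C@H]3O)c2o1` is carboxy in place of hydrogen on a saturated ring carbon: pyrrolidin-1-yl to 2-carboxypyrrolidin-1-yl. Among the compounds with values here, the only measured step, a number 27 percentage points lower from compound 1 to compound 2 (beyond the scatter), exchanges phenyl for furan-2-yl in another group, so it shows that this read-out can move but gives no direct size for carboxy. No step beyond the scatter is therefore expected in this assay. The estimated change is a number 2 percentage points higher from compound 3 to compound 4 (within the scatter). Compound 4 is expected at 12%, within a range of 2% to 28%.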

Compound 4, percent growth inhibition at one concentration: 0%
The estimate for compound 4 lay 12 percentage points above the measured number; measured number below the stated range.
By their numbers in this assay, from the lowest: compounds 4, 3 and 2 (each within the scatter of the next, the first and the last beyond it); then compound 1.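

In this assay, carboxy in place of hydrogen on the saturated ring carbon next to the ring nitrogen gives a number 10 percentage points lower from compound 3 to compound 4 (within the scatter). Within the data shown here, this is the first reading for a substituent on this ring, and it shows no change beyond the scatter, though compound 3 already stands at only 10%, which leaves little room for a further fall to show. Nothing available explains this reading.

From the compounds shown here alone, whether a methyl ester or a hydroxymethyl group on the same ring carbon would read differently remains open. So does whether carboxy would matter on a compound with a higher reading.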